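The source may hold more compounds than are shown below. What is called first, only, known or untested is meant among the compounds shown, and "the series" means these compounds.

Measured so far:
compound 1 `COc1cccc(OC)c1C(=O)Nc1c[nH]nc1C(=O)NC1CCCCCC1`: 42000 nM
compound 2 `CCc1ccccc1C(=O)Nc1c[nH]nc1C(=O)N[C@H]1CC[C@H](OC)CC1`: 3400 nM
compound 3 `CO[C@H]1CC[C@H](NC(=O)c2n[nH]cc2NC(=O)c2ccc(OC(F)F)cc2)CC1`: 2500 nM

In an ADME assay on MRC5 cells (Homo sapiens) for inhibition, with a stated time of 72 h (a lower number here means that less compound is needed, a higher number that more compound is needed for the effect), compound 1 gives the highest of the three numbers, with compound 2 at 3400 nM and compound 3 at 2500 nM both well beyond the scatter from it. Compound 4 `COc1cccc(OC)c1C(=O)Nc1c[nH]nc1C(=O)NC1CCC(C)CC1` is not yet measured in this assay. It differs from compound 1 by 4-methylcyclohexyl in place of cycloheptyl on an amide-type nitrogen. Among the measured compounds shown here, no step between two measured compounds isolates this change; compounds 2 and 3 carry another amide group as well as a different ring, so their values set no size for it. The step is expected to be small, likely within the scatter or a modest move to a lower number, as a 1.4-fold lower number from compound 1 to compound 4 (0.15 log units; within the scatter). Compound 4 is estimated at 30000 nM, within 12000 nM to 75000 nM.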

Compound 4, half-maximal effective concentration: 45000 nM
Compound 4: the middle estimate sits 1.5-fold (0.18 log units) below what was measured, within the range that was stated.
By their numbers in this assay, from the lowest: compounds 3 and 2 (each within the scatter of the next); then compounds 1 and 4 (each within the scatter of the next).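

In this assay the change on this amide-type nitrogen now has a measured size: 4-methylcyclohexyl in place of cycloheptyl gives a 1.1-fold higher number from compound 1 to compound 4 (0.03 log units; within the scatter) with the rest of compound 1 held fixed. On this core, the two carbon-only rings therefore cannot be told apart by this read-out. Nothing available explains this result.

Still open, going by these compounds, is whether an amine or a carboxylic acid on the ring would move the number on this core. Among the compounds shown here, no single step varies the other amide group of compound 1, so its contribution remains unread.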